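Piperazine acetamide series: cytotoxicity notes toward compound 4

The compounds below may be only part of what the source reports. "The series", "measured", "known", "first", "only" and "open" are said of these compounds alone.

Measured so far:
compound 1 `COc1ccc(NC(=O)CN2CCN(c3nnc(Cc4ccncc4)c4ccccc34)CC2)cc1OC` — 26500 nM
compound 2 `O=C(CN1CCN(c2nnc(Cc3ccccc3)c3ccccc23)CC1)Nc1c(F)cccc1F` — 84500 nM
compound 3 `COc1ccc(NC(=O)CN2CCN(c3nnc(Cc4ccccc4)c4ccccc34)CC2)cc1OC` — "not active" (no number reported)

In a functional assay on A549 cells (Homo sapiens) for cytotoxicity, read by MTT assay, with a stated time of 72 h (on this read-out higher numbers stand for weaker inhibition and lower numbers for stronger inhibition), compound 1 gives the lower of the two numbers; compound 2 gives the higher one, and the gap between them lies beyond the scatter. Compound 3 is reported in this assay as "not active" (no number reported), without a number. Compounds 1 and 2 differ from each other in more than one place, so no single change can be read from their gap.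

Compound 4 `Cc1ccccc1NC(=O)CN1CCN(c2nnc(Cc3ccncc3)c3ccccc23)CC1` has not been measured. It differs from compound 1 by one change: 2-methylphenyl in place of 3,4-dimethoxyphenyl on an amide-type nitrogen. Among the measured compounds shown here, no measured pair isolates this change; compound 3 shares the 3,4-dimethoxyphenyl of compound 1 but differs from it elsewhere as well. With nothing to anchor the direction, the step from compound 1 to compound 4 is expected to be small, a 1.5-fold higher number from compound 1 to compound 4 (0.18 log units; within the scatter), in either direction. Compound 4 is expected to give about 40000 nM in this assay, within 12000 nM to 130000 nM. Compound 3 gives "not active" (no number reported), so a report without a number cannot be ruled out for compound 4 either.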

Compound 4, half-maximal inhibitory concentration: 43100 nM
Compound 4: the middle estimate sits 1.1-fold (0.03 log units) below what was measured, and the stated range covers the measured number.
By their numbers in this assay, from the lowest: compounds 1, 4 and 2 (each within the scatter of the next, the first and the last beyond it).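

With the rest of compound 1 held fixed, this assay now has a single-change step on the amide-type nitrogen: 2-methylphenyl in place of 3,4-dimethoxyphenyl gives a 1.6-fold higher number from compound 1 to compound 4 (0.21 log units; within the scatter). The entering group has fewer heavy atoms and no hydrogen-bond acceptors, yet the step stays within the scatter, so this pair does not separate the two aryl groups at this position. No measured property is available that bears on this step.

Still open, from the compounds shown here alone, is how an aminophenyl group, a carboxyphenyl group or a longer alkyl chain on the amide-type nitrogen would read in this assay, and whether any of them would move the number beyond the scatter from compound 1. Going by these compounds, whether the same change reads alike on a different core also remains open.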